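The source may report more compounds than this note shows. Statements on the series, on what has been measured and on what is new or still open speak of the compounds shown alone.

Compound 3 `Nc1ccc(-c2cc(=O)c3c(N)c(F)c(C(=O)O)c(F)c3o2)cc1F` belongs with compound 1 `CCCCCCc1c(F)c(N)c2c(=O)cc(-c3ccc(N)c(F)c3)oc2c1F` and compound 2 `CCOC(=O)c1c(F)c(N)c2c(=O)cc(-c3ccc(N)c(F)c3)oc2c1F`, which share its core. In a functional assay on MCF7 cells (Homo sapiens) for cytotoxicity, read by neutral red uptake, with a stated time of 3 days (on this read-out lower numbers stand for stronger inhibition and higher numbers for weaker inhibition), compound 3 gives only a limit, > 10000 nM. Compound 1 likewise gives only a limit, > 10000 nM. Compound 2 gives 1400 nM. The spread of these three values is bounded by the limit of > 10000 nM in this assay, at which 2 of the 3 values shown sit. The readable steps are an at least 7.1-fold lower number from compound 1 to compound 2 (0.85 log units; beyond the scatter) and an at least 7.1-fold higher number from compound 2 to compound 3 (0.85 log units; beyond the scatter), whereas a step that the two limits leave unreadable from compound 1 to compound 3. Compound 4 `CCCCCC(=O)NCc1c(F)c(N)c2c(=O)cc(-c3ccc(N)c(F)c3)oc2c1F` differs from compound 3 by ((pentylcarbonyl)amino)methyl in place of carboxy on an aromatic carbon. Because the carboxy of compound 3 reads weaker than the ethoxycarbonyl of compound 2 by an at least 7.1-fold higher number from compound 2 to compound 3 (0.85 log units; beyond the scatter), the amide of compound 4 is expected to bring a lower number. Compound 4 is therefore estimated at 5000 nM, with a range from 1200 nM to 30000 nM. The expected step is an at least 2.0-fold lower number from compound 3 to compound 4 (0.30 log units; that floor lies within the scatter).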

Compound 4, half-maximal inhibitory concentration: 340 nM
Compound 4: middle estimate off by 15-fold (1.17 log units), on the high side; the whole stated range lies above it.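

In this assay, among the compounds shown here, the ((pentylcarbonyl)amino)methyl group gives compound 4 the lowest number of the four, and it improves even on the ethoxycarbonyl, the only earlier group with a measured number at this aromatic carbon (a 4.1-fold lower number from compound 2 to compound 4 (0.61 log units; beyond the scatter)). The gain over carboxy (an at least 29-fold lower number from compound 3 to compound 4 (1.46 log units; beyond the scatter)) and over the hexyl chain, where (pentylcarbonyl)amino replaces pentyl (an at least 29-fold lower number from compound 1 to compound 4 (1.46 log units; beyond the scatter)), is larger. Those two steps start from a limit and not from a number: the limit of > 10000 nM in this assay, at which 2 of the 4 values shown sit. The compounds shown leave open whether a shorter acyl chain, a longer one, a sulfonamide or a plain aminomethyl group here would read as low.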